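A few compounds are considered here, and "the series" means these few. Any claim that something is new, unique, unknown or untested is made for them only; others in the source may bear on it.

The measured compounds in an ADME assay on TZM-b1 cells (Homo sapiens) for cytotoxicity, read by XTT assay, with a stated time of 3 days; on this read-out lower numbers stand for higher toxicity in this test and higher numbers for lower toxicity in this test:

Compound 1 `Cc1nc(C(NC(=O)C(=O)Nc2ccc(F)cc2F)C2CCCCN2)sc1CO` gives > 87000 nM, which is a limit of the assay and not a number.
Compound 2 `Cc1nc(C(NC(=O)C(=O)Nc2ccc(Cl)cc2)C2CCCCN2)sc1CO` gives > 22000 nM, again a limit of the assay and not a number.
Compound 3 `Cc1nc(C(NC(=O)C(=O)Nc2ccc(C(F)(F)F)cc2)C2CCCCN2)sc1CO` gives > 75500 nM, also a limit of the assay and not a number.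

Compound 2 thus stands only as a limit in this assay, and the two other values shown are limits as well, so no order among the three compounds can be read. The steps a step that the two limits leave unreadable from compound 1 to compound 2, a step that the two limits leave unreadable from compound 1 to compound 3 and a step that the two limits leave unreadable from compound 2 to compound 3 are all unreadable for the same reason, and all three concern the group on the amide-type nitrogen. Compound 4 `Cc1nc(C(NC(=O)C(=O)Nc2ccc(Cl)cc2)C2CCCN2)sc1CO` differs from compound 2 by pyrrolidin-2-yl in place of piperidin-2-yl on a saturated chain carbon bound to an amide-type nitrogen and an aromatic carbon. Among the measured compounds shown here, none of the measured steps touches this position, so none bears directly on it. Because every value shown sits at a limit (the limit of > 22000 nM in this assay, at which 1 of the 3 values shown sits, (the limit of > 75500 nM in this assay, at which 1 of the 3 values shown sits), (the limit of > 87000 nM in this assay, at which 1 of the 3 values shown sits)), compound 4 is expected to show no step beyond the scatter, that is a step that the limit leaves unreadable from compound 2 to compound 4. For compound 4 the estimate in this assay is 50000 nM, within a range from 20000 nM to 150000 nM, most probably again reported only as a limit.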

Compound 4, half-maximal cytotoxic concentration: 12400 nM
The estimate for compound 4 lay 4.0-fold (0.61 log units) above the measured number; measured number outside the range, below it.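

Among the compounds shown here, compound 4 is the first compound here to give a number rather than a limit in this assay, and it does so after a change at a position the earlier compounds left untouched. Pyrrolidin-2-yl in place of piperidin-2-yl, on a saturated chain carbon bound to an amide-type nitrogen and an aromatic carbon, gives an at least 1.7-fold lower number from compound 2 to compound 4 (0.24 log units; that floor lies within the scatter). This size is only a floor, so the true step cannot be read, because compound 2 gives no number: the limit of > 22000 nM in this assay, at which 1 of the 4 values shown sits.

The compounds shown leave open whether the same ring change would give a step with 2,4-difluorophenyl or 4-(trifluoromethyl)phenyl on the amide-type nitrogen. They also leave open how an open-chain amine or a carboxylic acid at this place would read in this assay.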